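A Heteroaryl Sulfonamide Swap and Expected Microsomal Clearance

The source may report more compounds than this note shows. Statements on the series, on what has been measured and on what is new or still open speak of the compounds shown alone.

Three compounds sharing one core have been run in an ADME assay (liver) for metabolic stability, with Liver microsome (Homo sapiens) as the target, read by LC-MS, using microsomes and NADPH, with a stated time of 5 min, at 37 degrees C; a lower number here means slower removal, a higher number faster removal of the compound. Compound 1, `CCn1c([C@@H](C)NS(=O)(=O)c2ccc(Cl)cc2)nc2cc(F)c(Cl)cc21`, gives > 100 mL.min-1.g-1, which is a limit of the assay rather than a number. Compound 2, `CCn1c([C@@H](C)NS(=O)(=O)c2ccc(Cl)cc2)nc2ccc(CN(C)C)cc21`, gives 30 mL.min-1.g-1. Compound 3, `CCn1c([C@@H](C)NS(=O)(=O)c2ccc(CC(C)C)cc2)nc2ccc(C(F)(F)F)cc21`, also returns only a limit, > 100 mL.min-1.g-1. Compound 3 therefore stands at the limit of > 100 mL.min-1.g-1 in this assay, at which 2 of the 3 values shown sit, and no measured step among these three compounds involves a single structural change.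

Compound 4, `CCn1c([C@@H](C)NS(=O)(=O)c2cn(C)c(C)n2)nc2ccc(C(F)(F)F)cc21`, differs from compound 3 in one place: 1,2-dimethyl-1H-imidazol-4-yl in place of 4-isobutylphenyl on a sulfonyl sulfur. For the measured compounds named here, no step between measured compounds tells how such a change behaves here. Compound 2 shows that a member of this series can return a number within the measurable range of this assay, while compound 1 and compound 3 do not. The expectation for compound 4 is a drop in this assay from the limit toward a measurable value, estimated as an at least 2.5-fold lower number from compound 3 to compound 4 (0.39 log units; beyond the scatter). Compound 4 is therefore expected to give about 40 mL.min-1.g-1, with a likely range from 15 mL.min-1.g-1 to 100 mL.min-1.g-1, and a fair chance that only a limit is returned once more.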

Compound 4, intrinsic clearance in microsomes: 43 mL.min-1.g-1
Compound 4: middle estimate off by 1.1-fold (0.03 log units), on the low side; the range from low to high includes it.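

In this assay compound 3 gives > 100 mL.min-1.g-1, which is a limit of the assay and not a number. Replacing 4-isobutylphenyl with 1,2-dimethyl-1H-imidazol-4-yl on the sulfonyl sulfur gives an at least 2.3-fold lower number from compound 3 to compound 4 (0.36 log units; beyond the scatter), the first single change shown here that moves a compound off that limit and onto a measurable value, so the group at this place clearly affects how quickly the compound is removed in this assay. The step gives only a minimum for the true change, not its full size, and the limit remains common in this small set: the limit of > 100 mL.min-1.g-1 in this assay, at which 2 of the 4 values shown sit.

The swap alters several things at once, including the ring size, the ring atoms and the side chain, so this single pair cannot show which of them accounts for the lower number. From the compounds shown here alone, it also remains open whether a plain phenyl or a pyridin-3-yl ring on the sulfonyl sulfur would give a similar drop, and whether 1,2-dimethyl-1H-imidazol-4-yl would lower the number in the same way alongside the other groups on the core of compound 2.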